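Ester to Sulfonamide on the Saturated Ring: Expected Cytotoxicity

This account rests on a few compounds, and the source may have more. Where it says the series, first, only, none or still open, it means among the compounds named here.

Three compounds have been measured in an ADME assay on Vero cells (Chlorocebus sabaeus) for cytotoxicity, read by MTT assay, with a stated time of 48 h; on this read-out lower numbers stand for stronger inhibition and higher numbers for weaker inhibition:

Compound 1, `O=c1cc(N2CCN(CC3CCC(OS(=O)(=O)c4ccccc4)CC3)CC2)sc2c([N+](=O)[O-])cc(C(F)(F)F)cc12`, gives > 64 ug/mL.
Compound 2, `C=CC(=O)OC1CCC(CN2CCN(c3cc(=O)c4cc(C(F)(F)F)cc([N+](=O)[O-])c4s3)CC2)CC1`, gives > 64 ug/mL.
Compound 3, `O=C(OC1CCC(CN2CCN(c3cc(=O)c4cc(C(F)(F)F)cc([N+](=O)[O-])c4s3)CC2)CC1)c1ccncc1`, gives > 64 ug/mL.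

Compound 3 stands only at a limit of this assay, not at a number. The same holds for the other two values, so all three sit together at the limit of > 64 ug/mL in this assay, at which 3 of the 3 values shown sit. The three compounds differ only in the group attached through an oxygen on a saturated carbon, and the steps between them, a step that the two limits leave unreadable from compound 1 to compound 2, a step that the two limits leave unreadable from compound 1 to compound 3 and a step that the two limits leave unreadable from compound 2 to compound 3, cannot be sized because each end is a limit.

Compound 4, `O=c1cc(N2CCN(CC3CCC(NS(=O)(=O)c4ccccc4)CC3)CC2)sc2c([N+](=O)[O-])cc(C(F)(F)F)cc12`, is the next step from compound 3: (phenylsulfonyl)amino in place of ((pyridin-4-yl)carbonyl)oxy on a saturated ring carbon. The measured steps at this same place all left the read-out at the limit, and none gave a numerical reading below it; they therefore offer no sign that a change here moves this assay, though they cannot rule a step out either.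

Compound 4 is therefore expected to remain at the limit, estimated at 100 ug/mL with a range from 64 ug/mL to 200 ug/mL. The expected step is a step that the limit leaves unreadable from compound 3 to compound 4, none beyond the scatter.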

Compound 4, half-maximal inhibitory concentration: > 64 ug/mL
Compound 4: no number, only a limit; the forecaster's own chance of this, stated with the estimate: 85%; the middle value is on the limit's open side.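

In this assay compound 4 gives > 64 ug/mL, which is a limit of the assay and not a number. The steps to compound 4 from compound 1, compound 2 and compound 3 therefore cannot be read, as all four compounds sit together: the limit of > 64 ug/mL in this assay, at which 4 of the 4 values shown sit. Going by these compounds, how far each compound lies from that limit, and whether any change at this place moves the read-out, stays open.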